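Swapping trifluoromethyl for methyl on the benzyl group

The compounds below may be only part of what the source reports. "The series", "measured", "known", "first", "only" and "open" are said of these compounds alone.

Measured in a functional assay on MCF7 cells (Homo sapiens) for inhibition, read by CCK-8 assay, with a stated time of 48 h; a higher number here means a weaker inhibitor of growth, a lower number a stronger inhibitor of growth:
- compound 1 `CN1CCN(c2ccc(Nc3ncc(Cl)c(Nc4ccccc4)n3)nc2)CC1`: 51800 nM
- compound 2 `CN1CCN(c2ccc(Nc3ncc(Cl)c(NCc4ccc(C(F)(F)F)cc4)n3)nc2)CC1`: 28400 nM

Compound 2 has the lower of these two numbers, but repeat measurements of this kind vary, and the gap between the two compounds lies within that scatter. The pair therefore cannot be ranked.

Compound 3 `Cc1ccc(CNc2nc(Nc3ccc(N4CCN(C)CC4)cn3)ncc2Cl)cc1` has methyl in place of trifluoromethyl on an aromatic carbon, (methyl in place of trifluoromethyl on an aromatic carbon). The rest of compound 2 stays the same.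

Among the measured compounds shown here, only one measured step bears on this: a 1.8-fold lower number from compound 1 to compound 2 (0.26 log units; within the scatter). It replaced phenyl with 4-(trifluoromethyl)benzyl, so it does not test the new change directly. Even that larger change stayed within the scatter, so no step beyond the scatter is expected in this assay.

The estimated change is a 1.1-fold higher number from compound 2 to compound 3 (0.02 log units; within the scatter). For compound 3 the expected value is 30000 nM, with an estimated range of 13000 nM to 65000 nM.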

Compound 3, concentration for 50% growth inhibition: 38100 nM
Beside the measured number, compound 3's estimate is 1.3-fold (0.10 log units) below it; the range from low to high includes it.
By their numbers in this assay, from the lowest: compounds 2, 3 and 1 (each within the scatter of the next).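

In this assay, methyl in place of trifluoromethyl on this aromatic carbon gives a 1.3-fold higher number from compound 2 to compound 3 (0.13 log units; within the scatter), so this assay cannot tell these two groups apart, even though methyl has one heavy atom and trifluoromethyl has four. The other new comparison, 4-methylbenzyl in place of phenyl on the nitrogen, gives a 1.4-fold lower number from compound 1 to compound 3 (0.13 log units; within the scatter), so it shows no readable difference either, and the three compounds cannot be ranked. No measurement available here explains how either group acts at this position.

On these data alone, it remains open whether an amine, a carboxylic acid or a methoxy group on this aromatic carbon, para to a large group, would shift the number beyond the scatter. The same question applies to a longer chain in place of the benzyl group.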